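Adding a Second Methoxy Group to Compound 1

A few compounds are considered here, and "the series" means these few. Any claim that something is new, unique, unknown or untested is made for them only; others in the source may bear on it.

Compound 1, `COc1ccc(-c2cc(/C=C/C(=O)c3ccc(N)cc3)[nH]n2)cc1`: 4720 nM in a functional assay on SK-OV-3 cells (Homo sapiens) for inhibition, read by sulforhodamine B assay, with a stated time of 48 h; on this read-out lower numbers stand for stronger inhibition of growth and higher numbers for weaker inhibition of growth
Compound 2, `COc1cc(-c2cc(/C=C/C(=O)c3ccc(Cl)c(Cl)c3)[nH]n2)cc(OC)c1OC`: 4190 nM in this assay
Compound 3, `COc1cc(-c2cc(/C=C/C(=O)c3ccc(F)c(F)c3)[nH]n2)cc(OC)c1OC`: 3530 nM in this assay

Compound 1 has the highest of the three numbers in this assay, but the values of compound 2 and compound 3 lie within the usual scatter of it, so no order among the three can be read from them. Compound 4, `COc1ccc(-c2cc(/C=C/C(=O)c3ccc(N)cc3)[nH]n2)cc1OC`, is not yet measured in this assay. It differs from compound 1 by methoxy in place of hydrogen on an aromatic carbon, on the aryl ring attached to the shared core.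

Among the compounds with values here, the one step between measured compounds, a 1.2-fold lower number from compound 2 to compound 3 (0.07 log units; within the scatter), concerns the aryl ring on the carbonyl and not the ring changed here. Compound 2 and compound 3 both carry three methoxy groups on the core-side ring where compound 1 carries one, yet their numbers and that of compound 1 all sit within the scatter of each other. Nothing measured therefore points to a step beyond the scatter for the change from compound 1 to compound 4. Compound 4 is accordingly expected to give about 4200 nM in this assay, with a range of 1500 nM to 12000 nM, which amounts to an expected 1.1-fold lower number from compound 1 to compound 4 (0.05 log units; within the scatter).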

Compound 4, concentration for 50% growth inhibition: 4860 nM
Compound 4: the middle estimate sits 1.2-fold (0.06 log units) below what was measured; the measured number falls inside the stated range.
By their numbers in this assay, from the lowest: compounds 3, 2, 1 and 4 (each within the scatter of the next).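

In this assay, within the data shown here, the direct step, a 1.0-fold higher number from compound 1 to compound 4 (0.01 log units; within the scatter), isolates for the first time a single change on the aryl ring attached to the shared core: methoxy in place of hydrogen on an aromatic carbon, ortho to a methoxy group and meta to a large group, stays within the scatter. Compound 2 and compound 3 differ from compound 1 in more than one place, so they could not separate this change from the others, whereas this pair shows that adding the methoxy group to compound 1 gives no measurable shift in growth inhibition on this read-out. No independent measurement bears on why the number stays put.

The compounds shown leave open whether a hydroxyl, an ethoxy group or a fluorine at this same position would also stay within the scatter. They also leave open whether the added methoxy group would behave in the same way with a 3,4-dichlorophenyl or 3,4-difluorophenyl group on the carbonyl.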